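A few compounds are considered here, and "the series" means these few. Any claim that something is new, unique, unknown or untested is made for them only; others in the source may bear on it.

In a functional assay on the whole organism for positive allosteric modulation, with Mus musculus as the target (a lower number here means that less compound is needed, a higher number that more compound is needed for the effect), compound 1 (`CCC(=O)N(c1ccc(Cl)cc1)C1CCCC1N(C)C`) gives 3 mg/kg. It shares that number with compound 3 (`CCC(=O)N(c1cccc(C)c1)C1CCCC1N(C)C`), which gives 3 mg/kg; 3 mg/kg (2 entries) in both of its entries, so the two stand level. Compound 2 (`CCC(=O)N(c1ccc(OC)cc1)C1CCCC1N(C)C`) carries a methoxy group on the aromatic ring and stands apart from them, giving 30 mg/kg; 30 mg/kg (2 entries) in both of its entries, a higher dose on the same scale. Among these three compounds, then, compound 1 sits at the low-dose end of the numbers, together with compound 3.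

The next compound, compound 4 (`CCC(=O)N(c1ccc(Cl)c(C)c1)C1CCCC1N(C)C`), keeps the core of compound 1 and changes it in one place: methyl in place of hydrogen on an aromatic carbon. The new methyl stands on an aromatic carbon, ortho to a chloro group and meta to a large group. Among the measured compounds shown here, no measured pair isolates this change, so the evidence is indirect. Compound 3 also carries a methyl on the aromatic ring and gives 3 mg/kg; 3 mg/kg (2 entries), which suggests that a methyl is compatible with a low dose here. Compound 2 at 30 mg/kg; 30 mg/kg (2 entries) shows that the ring substituent can matter, which keeps the range wide. The expected step of no change at the digits printed from compound 1 to compound 4 (within the scatter) is none beyond the scatter, with no direction favoured. For compound 4 the estimated dose in this assay is 3 mg/kg, with an expected range of 1 mg/kg to 10 mg/kg.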

Compound 4, dose for half-maximal effect: 2 mg/kg
For compound 4 the middle estimate is 1.5-fold (0.18 log units) above the measured one, and the stated range covers the measured number.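

In this assay, methyl in place of hydrogen on an aromatic carbon, ortho to a chloro group and meta to a large group, can now be read directly, as a 1.5-fold lower number from compound 1 to compound 4 (0.18 log units; within the scatter), and this position therefore accepts the methyl without a step beyond the scatter. Compound 3 had shown a methyl on the aromatic ring only without a chloro group, whereas compound 4 carries both groups on the ring and stays within the scatter of compound 1. No measurement among those given bears on why the methyl leaves the dose within the scatter.

The compounds shown leave open whether this position would accept more than a methyl, for example an ethyl, an amine or a carboxylic acid, so the tolerance seen here rests on a single small group. They also leave open whether the same methyl would stay within the scatter on compound 2, which gives 30 mg/kg; 30 mg/kg (2 entries) and so stands apart from compound 1 and compound 3 in this assay.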